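This account rests on a few compounds, and the source may have more. Where it says the series, first, only, none or still open, it means among the compounds named here.

Measured in a physicochemical assay for solubility, read by HPLC, in phosphate buffer, at pH 6.5; a higher number here means a more soluble compound, a lower number a less soluble compound:
- compound 1 `COC(=O)C1=C(C)NC(c2nccs2)=NC1(C)c1ccc(F)cc1Cl`: 18 ug/mL
- compound 2 `COC(=O)C1=C(C)NC(c2nccs2)=NC1(C)c1ccc(Cl)cc1`: 14 ug/mL
- compound 3 `COC(=O)C1=C(CN2CCC(O)CC2)NC(c2nccs2)=NC1(C)c1ccc(F)cc1`: 593 ug/mL

Compound 3 stands highest of the three, beyond the scatter from both others. Compound 4 `COC(=O)C1=C(COCC(F)(F)F)NC(c2nccs2)=NC1(C)c1ccc(F)cc1` differs from it as follows: 2,2,2-trifluoroethoxy in place of 4-hydroxypiperidin-1-yl on a saturated chain carbon bound to a double-bonded ring carbon. Among the measured compounds shown here, the only measured step, a 1.3-fold lower number from compound 1 to compound 2 (0.11 log units; within the scatter), lies within the scatter and concerns a different place, so it does not bear directly on this change. For the measured compounds named here, compound 1 carries neither group and gives 18 ug/mL, so a fall towards that level is expected, though no measured compound carries 2,2,2-trifluoroethoxy. The expected step is a 15-fold lower number from compound 3 to compound 4 (1.17 log units; beyond the scatter), beyond the scatter. For compound 4 the estimate is 40 ug/mL, with an expected range of 12 ug/mL to 150 ug/mL.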

Compound 4, solubility: 19 ug/mL
The estimate for compound 4 lay 2.1-fold (0.32 log units) above the measured number, within the range that was stated.
By their numbers in this assay, from the lowest: compounds 2, 1 and 4 (each within the scatter of the next); then compound 3.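

This position is far from silent in this assay: 2,2,2-trifluoroethoxy in place of 4-hydroxypiperidin-1-yl gives a 31-fold lower number from compound 3 to compound 4 (1.49 log units; beyond the scatter), while the earlier step concerned a different place. The ring, nitrogen and hydrogen-bond donor all leave together in this change, so the pair cannot separate their contributions. No measurement on record accounts for the size of the step.

Open, on these data alone, is whether piperidin-1-yl without the hydroxyl, morpholin-4-yl or a carboxylic acid at this place would give a number near that of compound 3.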